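The source may report more compounds than this note shows. Statements on the series, on what has been measured and on what is new or still open speak of the compounds shown alone.

Values in a physicochemical assay for lipophilicity, at pH 7.4; a higher number here means a more lipophilic compound, a lower number a more polar compound:
- compound 1 `Cc1cc(C)c(CN2CCc3c(Cl)cc([C@H](CO)[C@H]4CCOC4)c(Cl)c3C2=O)c(=O)[nH]1`: 2
- compound 2 `COC(c1cc(Cl)c2c(c1Cl)C(=O)N(Cc1c(C)cc(C)[nH]c1=O)CC2)C1CCOC1`: 3; 3; 3; 3 (4 entries)
- compound 3 `COC(c1cc(Cl)c2c(c1Cl)C(=O)N(Cc1c(C)cc(C)[nH]c1=O)CC2)C1CCOCC1`: 3.4; 3.5 (2 entries)
- compound 4 `Cc1cc(C)c(CN2CCc3c(Cl)cc([C@H](C)CO)c(Cl)c3C2=O)c(=O)[nH]1`: not yet measured

Among the measured compounds shown here, compound 1 stands at 2, the only number for it, as two further entries carry none. This is a lower number than compound 2 at 3; 3; 3; 3 (4 entries) and compound 3 at 3.4; 3.5 (2 entries). Repeats agree closely where they can be compared, as seen in the several entries of compound 3 in this assay, 3.4; 3.5 (2 entries).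

The next compound to be measured is compound 4, which differs from compound 1 in a single place on an aromatic carbon, where 1-(hydroxymethyl)ethyl takes the place of the larger ring-bearing group: a group of 4 heavy atoms (3 carbon, 1 oxygen; no ring) in place of a group of 8 heavy atoms (6 carbon, 2 oxygen; one five-membered non-aromatic ring with 1 hetero atom), on an aromatic carbon. For the measured compounds named here, no pair of measured compounds differs in one place only, so the set offers no direct precedent for this change, and the expectation below is a judgement with a correspondingly wide range. A small step in this assay is expected, upward if it shows at all, and quite possibly none beyond the usual scatter. The expected change is a number 0.20 log units higher from compound 1 to compound 4 (within the scatter). For compound 4 the estimated value is 2.2, with an expected range of 1.7 to 2.7.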

Compound 4, distribution coefficient: 2.6
Beside the measured number, compound 4's estimate is 0.40 log units below it; the measured number falls inside the stated range.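

Among the compounds shown here, this is the first single-place comparison: in this assay, placing 1-(hydroxymethyl)ethyl on the aromatic carbon instead of the larger ring-bearing group gives a number 0.60 log units higher from compound 1 to compound 4 (beyond the scatter). The read-out therefore responds to a change at this position, and the group with fewer heavy atoms and no ring carries the higher number, so for this pair a smaller group does not mean a lower value. The step is clearly larger than the difference between repeat measurements in the series, so it can be read as a real difference between the two compounds and not as noise: the several entries of compound 3 in this assay, 3.4; 3.5 (2 entries)

This single pair changes several things at once, since the ring, the heavy-atom count, the hydrogen-bond acceptor count and the number of defined stereocentres all differ while the hydrogen-bond donor count stays the same, and it cannot show which of these goes with the step. From the compounds shown here alone, how a longer chain ending in the same hydroxyl, or an amine or a carboxylic acid in its place, would read at this aromatic carbon remains open.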